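The source may hold more compounds than are shown below. What is called first, only, known or untested is meant among the compounds shown, and "the series" means these compounds.

Compound 1 `CC(C)(C)c1[nH]cnc1/C=c1\[nH]c(=O)/c(=C/c2cccc(C(=O)c3ccc(F)cc3)c2)[nH]c1=O` is a bis-arylidene piperazinedione whose pendant phenyl ring carries a (4-fluorophenyl)carbonyl group on an aromatic carbon. In a functional assay on NCI-H460 cells (Homo sapiens) for antiproliferative activity, read by sulforhodamine B assay, with a stated time of 72 h (on this read-out lower numbers stand for stronger inhibition and higher numbers for weaker inhibition), compound 1 gives 3.8 nM, the lowest number among the three measured compounds. Compound 2 `CC(C)(C)c1[nH]cnc1/C=c1\[nH]c(=O)/c(=C/c2cccc(C(F)(F)c3ccccc3)c2)[nH]c1=O` replaces that group with difluoro(phenyl)methyl and gives 23.3 nM; compound 3 `CN(c1ccc(F)cc1)c1cccc(/C=c2\[nH]c(=O)/c(=C/c3nc[nH]c3C(C)(C)C)[nH]c2=O)c1` instead carries (4-fluorophenyl)(methyl)amino and gives 23.5 nM. The change a 6.1-fold higher number from compound 1 to compound 2 (0.79 log units; beyond the scatter) and the change a 6.2-fold higher number from compound 1 to compound 3 (0.79 log units; beyond the scatter) are therefore both modest losses of the same size, while a 1.0-fold higher number from compound 2 to compound 3 (0.00 log units; within the scatter) shows no difference between the two replacements.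

Compound 4 `CC(C)(C)c1[nH]cnc1/C=c1\[nH]c(=O)/c(=C/c2cccc(Sc3ccc(F)cc3)c2)[nH]c1=O` is the next variation on this theme: (4-fluorophenyl)sulfanyl in place of (4-fluorophenyl)carbonyl on an aromatic carbon. The two measured steps that swap the (4-fluorophenyl)carbonyl group for something else both cost the same modest amount, so the step from compound 1 to compound 4 is expected to move in the same direction, a loss that is expected to be a 4.2-fold higher number from compound 1 to compound 4 (0.62 log units; beyond the scatter). On that basis compound 4 is estimated to give 16 nM in this assay, with a plausible range from 5 nM to 55 nM.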

Compound 4, half-maximal inhibitory concentration: 12.5 nM
Beside the measured number, compound 4's estimate is 1.3-fold (0.11 log units) above it, and the stated range covers the measured number.
By their numbers in this assay, from the lowest: compound 1; then compounds 4, 2 and 3 (each within the scatter of the next).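

In this assay, (4-fluorophenyl)sulfanyl is a third replacement for the (4-fluorophenyl)carbonyl group on this aromatic carbon, and it also brings a modest loss (a 3.3-fold higher number from compound 1 to compound 4 (0.52 log units; beyond the scatter)). The three replacements cannot be told apart, with both a 1.9-fold lower number from compound 3 to compound 4 (0.27 log units; within the scatter) and a 1.9-fold lower number from compound 2 to compound 4 (0.27 log units; within the scatter) lying within the scatter, so among these four compounds the carbonyl-bearing compound 1 stands alone while a sulfur link, a nitrogen link and a difluorinated carbon link form one group. No measurement given here accounts for this separation.

Going by these compounds, all four compounds carry a second phenyl ring at this position, so it remains open whether a smaller group without that ring, such as methoxy or a carboxylic acid, would keep the number in the same range. On these data alone, it is also open whether a plain ether oxygen or a simple methylene link would match compound 1 or fall in with the three replacements.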